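LRRK2 G2019S Inhibitors: Swapping a Methyl for Oxolanyl

The source may report more compounds than this note shows. Statements on the series, on what has been measured and on what is new or still open speak of the compounds shown alone.

Measured so far:
Compound 1 `Cc1c(Nc2nc(N)c3c(C#N)c(N4CCC[C@H]4C)n(C)c3n2)cnn1C`: 43 nM
Compound 2 `C[C@@H]1CCCN1c1c(C#N)c2c(N)nc(Nc3cn[nH]c3)nc2n1C`: 6 nM
Compound 3 `C[C@@H]1CCCN1c1c(C#N)c2c(N)nc(Nc3cn(C)nc3Cl)nc2n1C`: 21 nM

In an assay on isolated protein for inhibition of Leucine-rich repeat serine/threonine-protein kinase 2 variant G2019S (Homo sapiens), read by TR-FRET and LanthaScreen, with stated times of 50 min and 30 min, in the presence of a further agent that is not named here (a higher number here means a weaker inhibitor, a lower number a stronger inhibitor), compound 1 gives the highest of the three numbers; compound 3 gives 21 nM and compound 2 gives 6 nM, so the steps of a 2.0-fold lower number from compound 1 to compound 3 (0.31 log units; beyond the scatter) and a 7.2-fold lower number from compound 1 to compound 2 (0.86 log units; beyond the scatter) both run downward from compound 1.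

Compound 4 `Cc1c(Nc2nc(N)c3c(C#N)c(N4CCC[C@H]4C)n(C)c3n2)cnn1[C@@H]1CCOC1` differs from compound 1 by oxolan-3-yl in place of methyl on an aromatic nitrogen. Within the data shown here, none of the measured steps touches this aromatic nitrogen: the steps of a 7.2-fold lower number from compound 1 to compound 2 (0.86 log units; beyond the scatter), a 2.0-fold lower number from compound 1 to compound 3 (0.31 log units; beyond the scatter) and a 3.5-fold higher number from compound 2 to compound 3 (0.54 log units; beyond the scatter) all alter other parts of the pyrazole. Among the measured compounds shown here, they show only that this pyrazole tolerates change without large swings. For the measured compounds named here, with no direct precedent, the expectation for compound 4 is a number close to compound 1, a 1.2-fold lower number from compound 1 to compound 4 (0.09 log units; within the scatter), giving an estimated 35 nM with a range from 12 nM to 110 nM in this assay.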

Compound 4, half-maximal inhibitory concentration: 12 nM
For compound 4 the middle estimate is 2.9-fold (0.46 log units) above the measured one; the range from low to high includes it.
By their numbers in this assay, from the lowest: compounds 2, 4 and 3 (each within the scatter of the next, the first and the last beyond it); then compound 1.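

Placing oxolan-3-yl on the aromatic nitrogen in place of methyl gives a 3.6-fold lower number from compound 1 to compound 4 (0.55 log units; beyond the scatter) in this assay. This nitrogen of the five-membered aromatic ring therefore accepts a much larger group, with a ring and a hydrogen-bond acceptor, and binding improves rather than suffers. No supporting data explain this gain.

As far as these compounds go, whether the gain depends on the ring oxygen or simply on the larger group remains open, and a cyclopentyl group would separate the two. Also open, from the compounds shown here alone, are the opposite stereocentre of oxolan-3-yl and a ring amine such as piperidin-4-yl.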